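Replacing Cyano with Nitro on an Aromatic Carbon

A few compounds are considered here, and "the series" means these few. Any claim that something is new, unique, unknown or untested is made for them only; others in the source may bear on it.

Among the compounds with values here, in a functional assay on SK-BR-3 cells (Homo sapiens) for antiproliferative activity, with a stated time of 48 h (on this read-out lower numbers stand for an effect already at smaller amounts and higher numbers for an effect only at larger amounts of compound), only two compounds have been measured so far. Compound 1 (`O=C(CCCCCCC(=O)Nc1ccc(C(F)(F)F)cc1)NO`) gives 2200 nM and compound 2 (`N#Cc1ccc(NC(=O)CCCCCCC(=O)NO)cc1`) gives 8800 nM as the higher of the two numbers. Within the data shown here, compound 3 (`O=C(CCCCCCC(=O)Nc1ccc([N+](=O)[O-])cc1)NO`) has no measurement yet. It differs from compound 2 by having nitro in place of cyano on an aromatic carbon. Among the measured compounds shown here, one measured step bears on this change, since it alters the same place: a 4.0-fold higher number from compound 1 to compound 2 (0.60 log units; beyond the scatter) in this assay and counts as modest. It shows that the group at this place can shift the number, but no measurement covers nitro itself. A smaller move toward a lower number is therefore expected, estimated as a 2.0-fold lower number from compound 2 to compound 3 (0.30 log units; within the scatter) with the direction uncertain. The estimated value for compound 3 is 4400 nM (expected range 1800 nM to 11000 nM).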

Compound 3, half-maximal effective concentration: 58000 nM
Compound 3: the middle estimate sits 13-fold (1.12 log units) below what was measured, outside the stated range (above it).
By their numbers in this assay, from the lowest: compound 1; then compound 2; then compound 3.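

In this assay nitro in place of cyano gives a 6.6-fold higher number from compound 2 to compound 3 (0.82 log units; beyond the scatter) and nitro in place of trifluoromethyl gives a 26-fold higher number from compound 1 to compound 3 (1.42 log units; beyond the scatter) on the same aromatic carbon, so this change is a clear loss rather than the small shift the earlier pair could have allowed. Within the data shown here, the three groups at this place now form an order, with trifluoromethyl giving the lowest number, cyano the next and nitro the highest, and the span from lowest to highest counts as large where the one earlier step counted as modest. Nothing available here explains why nitro gives the highest number of the three.

The compounds shown leave open where other groups at this place would fall, such as an amine or a carboxylic acid. They also leave open whether the same order would hold with a longer chain in the shared core.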